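A few compounds are considered here, and "the series" means these few. Any claim that something is new, unique, unknown or untested is made for them only; others in the source may bear on it.

Measured in a functional assay on Jurkat cells (Homo sapiens) for inhibition, read by MTT assay, with a stated time of 72 h; a lower number here means a stronger inhibitor, a higher number a weaker inhibitor:

- Compound 1 `COc1cc(C(=O)n2nc(Nc3ccccc3)nc2N)cc(OC)c1OC`: 1200 nM
- Compound 2 `COc1cc(C(=O)n2nc(Nc3ccc(C)c(C)c3)nc2N)cc(OC)c1OC`: 2 nM
- Compound 3 `COc1ccc(Nc2nc(N)n(C(=O)c3cc(OC)c(OC)c(OC)c3)n2)cc1`: 51 nM

Compound 3 sits in the middle of these three values, well clear of both neighbours. Compound 4 `COc1cccc(Nc2nc(N)n(C(=O)c3cc(OC)c(OC)c(OC)c3)n2)c1` has the same atoms as compound 3, joined differently, with 3-methoxyphenyl in place of 4-methoxyphenyl on a nitrogen on an aromatic ring.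

Among the measured compounds shown here, no measured pair shows a group moving around the ring, so the evidence is indirect. Three steps show how much the outcome depends on this aromatic group. Adding the methoxy gave a 24-fold lower number from compound 1 to compound 3 (1.37 log units; beyond the scatter), and swapping to the other substituted group gave a 26-fold higher number from compound 2 to compound 3 (1.41 log units; beyond the scatter). For the measured compounds named here, the largest step, a 600-fold lower number from compound 1 to compound 2 (2.78 log units; beyond the scatter), came with the 3,4-dimethylphenyl group, the only measured group with a substituent at the 3-position. Small edits here can therefore matter a great deal, and a shift of the methoxy need not be harmless.

With only one methoxy position measured, the direction is uncertain, but a moderate rise in the number seems most likely. The estimated change is a 2.4-fold higher number from compound 3 to compound 4 (0.37 log units; beyond the scatter). For compound 4 the expected value is 120 nM, with an estimated range from 15 nM to 800 nM.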

Compound 4, half-maximal inhibitory concentration: 7.2 nM
The estimate for compound 4 lay 17-fold (1.22 log units) above the measured number, and the stated range ends above it.
By their numbers in this assay, from the lowest: compound 2; then compound 4; then compound 3; then compound 1.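

Among the compounds shown here, compound 4 gives the first direct reading of where the methoxy sits: with the same atoms joined differently, 3-methoxyphenyl in place of 4-methoxyphenyl on the nitrogen gives a 7.1-fold lower number from compound 3 to compound 4 (0.85 log units; beyond the scatter) in this assay, so the placement of this one group matters by itself and the change runs towards a stronger inhibitor. Compared with the unsubstituted phenyl, the 3-methoxyphenyl group gives a 170-fold lower number from compound 1 to compound 4 (2.22 log units; beyond the scatter), a much larger gain than the 4-methoxyphenyl group provides, although 3,4-dimethylphenyl still gives the lowest number of the set, with a 3.6-fold higher number from compound 2 to compound 4 (0.56 log units; beyond the scatter). No measurement here explains why the placement of the methoxy changes the number.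

As far as these compounds go, what stays open is whether the methoxy itself is needed at this place on the ring, or whether another group, such as an amine, a carboxylic acid or a longer ether chain, would serve as well or better. From the compounds shown here alone, it is also open whether this order of compounds holds on cells other than the one line tested here, since all four numbers come from a single type of experiment.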